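The compounds below may be only part of what the source reports. "The series", "measured", "known", "first", "only" and "open" are said of these compounds alone.

The compounds here share one core, a six-membered saturated ring with two nitrogen atoms, one carrying an acetyl group and the other a fluorophenylsulfonyl group; they differ only in the group on a saturated ring carbon. Compound 1 is `CC(=O)N1CCN(S(=O)(=O)c2ccc(F)cc2)CC1CO` and compound 2 is `COCC1CN(C(C)=O)CCN1S(=O)(=O)c1ccc(F)cc1`. Both were tested in a physicochemical assay for metabolic stability, read by LC-MS, in phosphate buffer, tested at 1 uM; a lower number here means that the compound disappears faster, a higher number that the compound lasts longer. In this assay compound 1 gives >= 4 h, which is a limit of the assay rather than a number. Compound 2 likewise gives >= 4 h in this assay, again a limit. So compound 1 stands at the limit of >= 4 h in this assay, at which 2 of the 2 values shown sit, and nothing among the measured compounds separates it from compound 2.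

Compound 3 is `CCOC(=O)C1CN(S(=O)(=O)c2ccc(F)cc2)CCN1C(C)=O`. It differs from compound 1 in a single way: ethoxycarbonyl in place of hydroxymethyl on a saturated ring carbon.

Among the compounds with values here, no measured pair isolates this kind of change, so the expectation rests on the two limits alone. Compound 3 is expected to show no step beyond the usual scatter in this assay, that is a number no higher from compound 1 to compound 3 (the limit leaves the size open). Accordingly, compound 3 is estimated at 4 h in this assay, most likely between 1.5 h and 10 h.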

Compound 3, half-life: >= 4 h
Compound 3: only a limit was reported (the forecaster's own chance of this, stated with the estimate: 65%); the middle value lies on the limit itself.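

In this assay compound 3 gives >= 4 h, which is a limit and not a number. Within the data shown here, compound 1 is also reported only as a limit, so no step from compound 1 to compound 3 can be read. Still open is how long each compound actually lasts, and whether ethoxycarbonyl in place of hydroxymethyl makes any difference: the limit of >= 4 h in this assay, at which 3 of the 3 values shown sit.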